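Methoxy on the aryl ring of extended dienone analogues

The compounds below may be only part of what the source reports. "The series", "measured", "known", "first", "only" and "open" are said of these compounds alone.

Three compounds have been measured in a functional assay on HeLa cells (Homo sapiens) for cytotoxicity, read by sulforhodamine B assay, with a stated time of 48 h; on this read-out lower numbers stand for stronger inhibition and higher numbers for weaker inhibition:

Compound 1, `CC1=C(/C=C/C(=O)/C=C/c2ccccc2)C(C)(C)CCC1`, gives 70200 nM.
Compound 2, `COc1ccccc1/C=C/C(=O)/C=C/C1=C(C)CCCC1(C)C`, gives 88200 nM.
Compound 3, `CC1=C(/C=C/C(=O)/C=C/C=C/c2ccccc2)C(C)(C)CCC1`, gives only a limit in this assay, > 100000 nM.

Compound 2 differs from compound 1 by a single change, (methoxy in place of hydrogen on an aromatic carbon). This step, a 1.3-fold higher number from compound 1 to compound 2 (0.10 log units; within the scatter), leaves the two values within the scatter of each other, so no order between compound 1 and compound 2 can be read from it. Compound 3 differs from compound 1 in more than one place, and the difference between the two cores is not broken down here. The value of compound 3 is not a number but (the limit of > 100000 nM in this assay, at which 1 of the 3 values shown sits).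

Compound 4, `COc1ccccc1/C=C/C=C/C(=O)/C=C/C1=C(C)CCCC1(C)C`, has not yet been measured. It stands to compound 3 as compound 2 stands to compound 1: the difference is methoxy in place of hydrogen on an aromatic carbon, and the place of the change is described in the same words for both pairs, so this is the same change made on a different core. Because the earlier step of this change, a 1.3-fold higher number from compound 1 to compound 2 (0.10 log units; within the scatter), lies within the scatter, the expectation for compound 4 is a step of similar size, a step that the limit leaves unreadable from compound 3 to compound 4, from a starting point that is itself only a limit. Compound 4 is therefore estimated at 150000 nM, and since compound 3 gives > 100000 nM, compound 4 is expected most likely to return a limit as well, in the range 70000 nM to 400000 nM.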

Compound 4, half-maximal inhibitory concentration: 33500 nM
Beside the measured number, compound 4's estimate is 4.5-fold (0.65 log units) above it; the measured number lies below the stated range.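

In this assay, placing methoxy in place of hydrogen on the aromatic carbon of the core of compound 3, the change from phenyl to 2-methoxyphenyl, gives an at least 2.9-fold lower number from compound 3 to compound 4 (0.47 log units; beyond the scatter). The same change therefore does not carry over with a single size from one core to the other, and on the core of compound 1 it leaves no readable order: the same change on two cores in this assay, a 1.3-fold higher number (0.10 log units; within the scatter) from compound 1 to compound 2 and an at least 2.9-fold lower number (0.47 log units; beyond the scatter) from compound 3 to compound 4, at least 3.7-fold (0.57 log units) apart, beyond the scatter of two such steps Compound 3 gives > 100000 nM, a limit of the assay and not a number, so the step on this core is known only as a bound, and two pairs do not show why the cores differ or how the change would behave on any further core.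

The compounds shown leave open whether methoxy at another place on the aromatic ring would give a step of this kind, and whether a different group at the same place, such as hydroxyl, chlorine or an amine, would follow compound 2 or compound 4 in this assay. They also leave open whether the change would keep its larger step on a core with a still longer chain, or whether the step seen here belongs to compound 3 and compound 4 alone.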